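Ring to Chain at the Aminomethyl Arm

This account rests on a few compounds, and the source may have more. Where it says the series, first, only, none or still open, it means among the compounds named here.

Measured in a functional assay on the whole organism (strain CF-1) for positive allosteric modulation, with Mus musculus as the target; a lower number here means that less compound is needed, a higher number that more compound is needed for the effect:
Compound 1, `Cc1nnc(CN(C)C)n1-c1ccc(Cl)cc1C(=O)c1ccccc1`, gives 1.1 mg/kg.
Compound 2, `Cc1nnc(CN(C)C)n1-c1ccccc1C(=O)c1ccccc1Cl`, gives only a limit of the assay, > 100 mg/kg.
Compound 3, `Cc1nnc(CN2CCCC2)n1-c1ccc(Cl)cc1C(=O)c1ccccc1Cl`, gives 6 mg/kg.

Compound 3 holds the highest of the two numbers in this assay. The nearest number belongs to compound 1, which sits lower by a gap beyond the usual scatter. Compound 2 contributes no number, only a limit (the limit of > 100 mg/kg in this assay, at which 1 of the 3 values shown sits).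

Compound 4, `Cc1nnc(CN(C)C)n1-c1ccc(Cl)cc1C(=O)c1ccccc1Cl`, has not yet been measured. It differs from compound 3 in one place: dimethylamino in place of pyrrolidin-1-yl on a saturated chain carbon bound to an aromatic carbon. Among the compounds with values here, no pair of measured compounds shows this exact change on its own, so no measured step tells its size. Compound 1 carries the same dimethylamino group and gives 1.1 mg/kg, which points toward a lower number rather than a higher one, though compound 1 differs from compound 4 in other places too. A small step toward a lower number, or none beyond the scatter, is expected; the step of a 2.0-fold lower number from compound 3 to compound 4 (0.30 log units; within the scatter) is the estimate. Compound 4 is estimated at 3 mg/kg, between 1 mg/kg and 10 mg/kg.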

Compound 4, dose for half-maximal effect: 0.63 mg/kg
Compound 4: the middle estimate sits 4.8-fold (0.68 log units) above what was measured; the whole stated range lies above it.
By their numbers in this assay, from the lowest: compounds 4 and 1 (each within the scatter of the next); then compound 3. At a limit, above all of these: compound 2.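

The change from ring to chain at this arm now has a measured size in this assay: dimethylamino in place of pyrrolidin-1-yl on a saturated chain carbon bound to an aromatic carbon gives a 9.5-fold lower number from compound 3 to compound 4 (0.98 log units; beyond the scatter). Chloro in place of hydrogen on an aromatic carbon has very different outcomes at two different carbons, with an at least 150-fold lower number from compound 2 to compound 4 (2.20 log units; beyond the scatter) at one and a 1.7-fold lower number from compound 1 to compound 4 (0.24 log units; within the scatter) at the other. Compound 2 gives a limit, not a number: the limit of > 100 mg/kg in this assay, at which 1 of the 4 values shown sits.

The ring-to-chain step rests on this single pair of compounds, and it cannot be said whether it would hold on another core. Going by these compounds, how a larger amine such as diethylamino or piperidin-1-yl would compare on the same arm remains open, as does the effect of fluoro in place of either chloro.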